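Benzyl versus cyclopropylmethyl on the shared core

A few compounds are considered here, and "the series" means these few. Any claim that something is new, unique, unknown or untested is made for them only; others in the source may bear on it.

Measured in an assay on isolated protein for binding affinity to corticotropin-releasing factor receptor 1 (Homo sapiens) (on this read-out higher numbers stand for weaker inhibition and lower numbers for stronger inhibition), so far:
compound 1 `CCCN(Cc1ccccc1)c1nc(C)nc(Nc2ccc(C)cc2)n1` gives > 10000 nM, a limit of the assay.
compound 2 `CCCN(Cc1ccccc1)c1nc(C)nc(Nc2c(C)cc(C)cc2C)n1` gives 490 nM.
compound 3 `CCCN(CC1CC1)c1nc(C)nc(Nc2c(C)cccc2C)n1` gives > 10000 nM, again a limit.

Compound 3 thus sits at the limit of > 10000 nM in this assay, at which 2 of the 3 values shown sit; its number is not known. Compound 4 `CCCN(Cc1ccccc1)c1nc(C)nc(Nc2c(C)cccc2C)n1` differs from it by phenyl in place of cyclopropyl on a saturated chain carbon bound to a nitrogen on an aromatic ring. For the measured compounds named here, no measured step covers this change: the single step known, an at least 20-fold lower number from compound 1 to compound 2 (1.30 log units; beyond the scatter), concerns the aryl on the nitrogen on the aromatic ring and is large, but at a different place. Compound 2 carries the same benzyl as compound 4 and gives a number, compound 3 does not, so the direction for compound 4 is expected to be toward lower numbers, an at least 4.0-fold lower number from compound 3 to compound 4 (0.60 log units; beyond the scatter), though a limit remains possible. Compound 4 is estimated at 2500 nM, between 500 nM and 10000 nM.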

Compound 4, inhibition constant: > 10000 nM
Compound 4: only a limit was reported; the forecaster's own chance of this, stated with the estimate: 35%; middle value at least 4.0-fold (0.60 log units) away from the limit.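

With benzyl held fixed, hydrogen in place of methyl on an aromatic carbon gives an at least 20-fold higher number from compound 2 to compound 4 (1.30 log units; beyond the scatter), so in this assay 2,4,6-trimethylphenyl is the only aryl shown that gives a number, while 2,6-dimethylphenyl and 4-methylphenyl do not. The steps to compound 4 from compound 3 and from compound 1 cannot be read, as both ends of each are limits. Compound 4 is itself only a limit, like most of the series: the limit of > 10000 nM in this assay, at which 3 of the 4 values shown sit.

From the compounds shown here alone, how cyclopropylmethyl behaves alongside 2,4,6-trimethylphenyl remains open. Also open, going by these compounds, is whether a methoxy or a chloro group on that aromatic carbon would keep a measurable number.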